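Solubility across an ester and acid pair

The compounds below may be only part of what the source reports. "The series", "measured", "known", "first", "only" and "open" are said of these compounds alone.

Compound 1 `CCCCCOCc1[nH]c2ccc([N+](=O)[O-])cc2c(=O)c1C(=O)OCC` carries an ethyl ester and a pentyloxy group. Compound 2 `CCOCCCCc1[nH]c2ccc([N+](=O)[O-])cc2c(=O)c1C(=O)OCC` keeps the ester, and compound 3 `CCCCCOCc1[nH]c2ccc([N+](=O)[O-])cc2c(=O)c1C(=O)O` keeps the pentyloxy group. Compound 4 `CCOCCCCc1[nH]c2ccc([N+](=O)[O-])cc2c(=O)c1C(=O)O` is not yet measured.

In a physicochemical assay for solubility, read by HPLC, at pH 7.4 (on this read-out higher numbers stand for higher solubility and lower numbers for lower solubility), compound 1 gives 15000 nM. In this assay compound 2 gives 5000 nM, and compound 3 gives 50000 nM, the highest number of the three. The change 3-ethoxypropyl in place of pentyloxy on a saturated chain carbon bound to an aromatic carbon gave a 3.0-fold lower number from compound 1 to compound 2 (0.48 log units; beyond the scatter). The change in the core between compound 1 and compound 3 is hydrogen in place of ethyl on an oxygen next to a carbonyl group, and it gave a 3.3-fold higher number from compound 1 to compound 3 (0.52 log units; beyond the scatter).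

From compound 3 to compound 4 the change is 3-ethoxypropyl in place of pentyloxy on a saturated chain carbon bound to an aromatic carbon. The place is the same, word for word, as in the pair of compound 1 and compound 2, so this is the same change on the acid core rather than the ester core. For the measured compounds named here, with only one measured example, the step is expected to repeat at about the size seen before, because a 3.0-fold lower number from compound 1 to compound 2 (0.48 log units; beyond the scatter) is the only guide available. The step from compound 3 to compound 4 is therefore estimated as a 2.9-fold lower number from compound 3 to compound 4 (0.47 log units; beyond the scatter). Compound 4 is expected to give about 17000 nM, between 7000 nM and 40000 nM, in this assay.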

Compound 4, solubility: 50000 nM
Compound 4: middle estimate off by 2.9-fold (0.47 log units), on the low side; measured number outside the range, above it.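

In this assay, 3-ethoxypropyl in place of pentyloxy gave a 3.0-fold lower number from compound 1 to compound 2 (0.48 log units; beyond the scatter) with the ethyl ester kept, but on the acid it gives no change at the digits printed from compound 3 to compound 4 (within the scatter), so the step seen on the ester did not carry over to the acid. Hydrogen in place of ethyl gives a 10-fold higher number from compound 2 to compound 4 (1.00 log units; beyond the scatter) with the 3-ethoxypropyl chain, set against a 3.3-fold higher number from compound 1 to compound 3 (0.52 log units; beyond the scatter) with pentyloxy, so in these four compounds the size of each change depends on what stands at the other place. With a single pair on each core, this shows that a step read on one core cannot be taken as a guide to the other here, but it does not show a rule for the series, and nothing measured here speaks to the reason.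

As far as these compounds go, whether an amine or a longer chain at this place would follow the ester pair or the acid pair remains open. So does whether an amide in place of the acid would keep the two chains level.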